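Replacing the Aryl Group with Propyl at the Saturated Carbon

The compounds below may be only part of what the source reports. "The series", "measured", "known", "first", "only" and "open" are said of these compounds alone.

Compound 1 `CC1=C(C(=O)OCc2cccnc2)C(c2ccc(C#N)cc2)C2=C(CCCC2=O)N1` gives 1.36 in a physicochemical assay for lipophilicity, measured as octanol-water partition (a lower number here means a more polar compound, a higher number a more lipophilic compound), the lowest of the three numbers; compound 2 `CC1=C(C(=O)OCc2ccccn2)C(c2cccs2)C2=C(CCCC2=O)N1` gives 1.77 and compound 3 `CC1=C(C(=O)OCc2ccccn2)C(c2ccccc2)C2=C(CCCC2=O)N1` gives 2.72, both beyond the scatter above compound 1. Compound 4 `CCCC1C(C(=O)OCc2cccnc2)=C(C)NC2=C1C(=O)CCC2` is not yet measured. It differs from compound 1 by propyl in place of 4-cyanophenyl on a saturated ring carbon.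

For the measured compounds named here, the only measured step at this position, a number 0.95 log units higher from compound 2 to compound 3 (beyond the scatter), shows that exchanging one group on the saturated ring carbon can move the number modestly. Going by the values given here, no measured step exchanges an aryl group for a chain, and none removes a nitrile, so the 4-cyanophenyl to propyl change has no direct precedent here. Still, the loss of the nitrile, the single hydrogen-bond acceptor counted in the leaving group, makes a rise beyond the scatter the more likely outcome. Compound 4 is therefore expected to come out higher, with an estimated step of a number 0.59 log units higher from compound 1 to compound 4 (beyond the scatter) and a value of about 1.95, in the range from 1.45 to 2.5.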

Compound 4, partition coefficient: 2.23
Compound 4: the middle estimate sits 0.28 log units below what was measured, within the range that was stated.
By their numbers in this assay, from the lowest: compound 1; then compound 2; then compound 4; then compound 3.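

In this assay, for the compounds shown here, the exchange of 4-cyanophenyl for propyl on the saturated ring carbon gives a number 0.87 log units higher from compound 1 to compound 4 (beyond the scatter), the first measured step at this position that replaces an aryl group with a chain. It shows that the number here responds beyond the scatter not only to an exchange between two ring groups but also to a chain with no ring taking the place of a ring group. Nothing shown gives a cause for this rise.

The step removes the six-membered aromatic ring and the nitrile together, and the compounds shown do not separate the two. On these data alone, how a longer chain, an unsubstituted phenyl on the core of compound 1, or an amine at this carbon would compare with propyl remains open.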